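A few compounds are considered here, and "the series" means these few. Any claim that something is new, unique, unknown or untested is made for them only; others in the source may bear on it.

In a functional assay on CCRF-CEM cells (Homo sapiens) for inhibition (a higher number here means a weaker inhibitor, a lower number a stronger inhibitor), compound 2 `CCC(C)C(NC(=O)NO)C(=O)NC(c1ccccc1)c1ccccc1` gives 107000 nM and compound 3 `CCC(C)C(NC(=O)n1nnc2ccccc21)C(=O)NC(c1ccccc1)c1ccccc1` gives 139000 nM. The two differ at the group on the carbonyl carbon, and a 1.3-fold higher number from compound 2 to compound 3 (0.11 log units; within the scatter) places them within the scatter of each other. Compound 1 `CCC(C)C1NC(=O)N(C2CCCCC2)C1=O` reads > 200000 nM, which is a limit of the assay and not a number. Compound 3 therefore stands level with compound 2, and both give actual numbers.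

Compound 4 `CCC(C)C(NC(=O)n1nnc2ccccc21)C(=O)NCc1ccccc1` follows from compound 3 by one change: hydrogen in place of phenyl on a saturated chain carbon bound to an amide-type nitrogen and an aromatic carbon. In words, hydrogen replaces phenyl on a saturated chain carbon bound to an amide-type nitrogen and an aromatic carbon. Among the measured compounds shown here, no measured step tests this change directly. For the measured compounds named here, the only measured step, a 1.3-fold higher number from compound 2 to compound 3 (0.11 log units; within the scatter), concerns the group on the carbonyl carbon, so it offers only weak guidance: a large swap there left compound 3 at 139000 nM. On that slim basis, no step beyond the scatter is expected in this assay, and no direction can be favoured. The expected step is a 1.0-fold higher number from compound 3 to compound 4 (0.00 log units; within the scatter). Like compound 1, compound 4 could also return only a limit. For compound 4 the estimated value is 140000 nM, with an expected range from 60000 nM to 200000 nM.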

Compound 4, half-maximal inhibitory concentration: 164000 nM
For compound 4 the middle estimate is 1.2-fold (0.07 log units) below the measured one; measured number inside the range.
By their numbers in this assay, from the lowest: compounds 2, 3 and 4 (each within the scatter of the next). At a limit, above all of these: compound 1.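

In this assay, hydrogen in place of phenyl on a saturated chain carbon bound to an amide-type nitrogen and an aromatic carbon gives a 1.2-fold higher number from compound 3 to compound 4 (0.07 log units; within the scatter), so losing this phenyl, with its six-membered aromatic ring, leaves the reading unchanged within the scatter. Among the compounds shown here, this is the first measured step at this position, and it adds to the earlier step on the carbonyl carbon, a 1.3-fold higher number from compound 2 to compound 3 (0.11 log units; within the scatter): two quite different changes, in two places, have now each stayed within the scatter. The only limit shown belongs to compound 1, and it is a limit of the assay and not a number: the limit of > 200000 nM in this assay, at which 1 of the 4 values shown sits.

Going by these compounds, what remains open is whether any group on this saturated chain carbon can move the number beyond the scatter in either direction, for instance an amine, a carboxylic acid or a longer chain in place of the hydrogen of compound 4. Also open, on these data alone, is whether the change at this position would give the same small step with the group carried by compound 2 on the carbonyl carbon, since the step here was read only with the group carried by compound 3.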